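Sulfonyl substituent swap within the aryl-alkynyl phenoxyacetic acid series

The source may report more compounds than this note shows. Statements on the series, on what has been measured and on what is new or still open speak of the compounds shown alone.

Of the compounds shown here, two carry numbers so far. Compound 1 `COc1ccccc1C#Cc1cc(Cl)ccc1OCC(=O)O` gives 190 nM in an assay on CHO cells for displacement of a labelled ligand from prostaglandin D2 receptor 2 (Homo sapiens), read by scintillation counting; on this read-out higher numbers stand for weaker inhibition and lower numbers for stronger inhibition. Compound 2 `Cc1ccc(S(=O)(=O)Cc2ccccc2)cc1C#Cc1cc(Cl)ccc1OCC(=O)O` gives 5 nM in this assay, the lowest of the two numbers; against compound 1 its number sits a long way lower, well beyond the scatter of repeat measurements.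

Compound 3 `Cc1ccc(S(=O)(=O)N(C)C(C)C)cc1C#Cc1cc(Cl)ccc1OCC(=O)O` has not been measured. It differs from compound 2 in one place: isopropyl(methyl)amino in place of benzyl on a sulfonyl sulfur. The acid-bearing core and the alkyne link are unchanged, as is the methyl on the distal ring.

Within the data shown here, no measured pair in this set spans that kind of change, so there is no step to lean on. The expectation is that compound 3 stays in the same neighbourhood as compound 2, with a modest move towards a higher number that may or may not clear the scatter. Compound 3 is expected at about 12 nM in this assay. The range for compound 3 is estimated as 3 nM to 50 nM. The step expected is a 2.4-fold higher number from compound 2 to compound 3 (0.38 log units; beyond the scatter).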

Compound 3, inhibition constant: 3.8 nM
Estimate against measurement, compound 3: 3.2-fold (0.50 log units) above, and the stated range covers the measured number.
By their numbers in this assay, from the lowest: compounds 3 and 2 (each within the scatter of the next); then compound 1.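

In this assay, isopropyl(methyl)amino in place of benzyl on a sulfonyl sulfur gives a 1.3-fold lower number from compound 2 to compound 3 (0.12 log units; within the scatter), a step within the scatter. At this place, therefore, a low number does not depend on the six-membered aromatic ring of benzyl: a group with no ring and a nitrogen bonded to the sulfonyl sulfur reads the same, so benzylsulfonyl and isopropyl(methyl)sulfamoyl cannot be separated on this read-out. No supporting measurement is available to explain why the two groups read alike.

Still open, as far as these compounds go, is how far this tolerance extends among amines on the same sulfonyl sulfur, for example whether the smaller dimethylamino, the secondary isopropylamino or the cyclic piperidine would stay level with the isopropyl(methyl)amino group. From the compounds shown here alone, on the carbon side, it also remains open whether a plain methyl or a longer alkyl chain on the sulfonyl sulfur would hold the number seen with benzyl, since a single pair cannot show which parts of either group matter.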